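Working notes: halogen swap on the benzoyl cap

The source may hold more compounds than are shown below. What is called first, only, known or untested is meant among the compounds shown, and "the series" means these compounds.

Values in a functional assay on OCI-Ly3 cells (Homo sapiens) for inhibition, read by CellTiter-Glo, with stated times of 48 h and 96 h; a higher number here means a weaker inhibitor of growth, a lower number a stronger inhibitor of growth:
- compound 1 `CCC(=O)[C@H](CCCNC(=N)N)NC(=O)[C@@H]1CCCN1C(=O)[C@@H](NC(=O)[C@H](CC(C)C)NC(=O)OCc1ccccc1)C(C)C`: > 20000 nM
- compound 2 `CC(C)[C@H](NC(=O)c1ccccc1Br)C(=O)N1CCC[C@H]1C(=O)N[C@@H](CCCNC(=N)N)C(=O)CF`: 4240 nM
- compound 3 `CC(C)[C@H](NC(=O)c1cccc(Br)c1)C(=O)N1CCC[C@H]1C(=O)N[C@@H](CCCNC(=N)N)C(=O)CF`: 530 nM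

The entry for compound 1 is a limit of the assay and not a number. Of the two actual numbers in this assay, compound 3 holds the lower.

Next comes compound 4 `CC(C)[C@H](NC(=O)c1ccc(Cl)cc1)C(=O)N1CCC[C@H]1C(=O)N[C@@H](CCCNC(=N)N)C(=O)CF`, where 4-chlorophenyl stands in place of 3-bromophenyl on a carbonyl carbon: 4-chlorophenyl in place of 3-bromophenyl on a carbonyl carbon. Within the data shown here, one measured step bears on this place, a change from 2-bromophenyl to 3-bromophenyl: an 8.0-fold lower number from compound 2 to compound 3 (0.90 log units; beyond the scatter). That step shows that a change here can exceed the scatter, but it does not fix a direction for 4-chlorophenyl. Among the measured compounds shown here, no measured compound carries that group. A smaller step than that one is expected, leaning slightly towards a higher number. The estimated step is a 1.3-fold higher number from compound 3 to compound 4 (0.12 log units; within the scatter). For compound 4 the expected value in this assay is 700 nM, with an estimated range of 230 nM to 2400 nM.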

Compound 4, concentration for 50% growth inhibition: 1240 nM
For compound 4 the middle estimate is 1.8-fold (0.25 log units) below the measured one; the measured number falls inside the stated range.
By their numbers in this assay, from the lowest: compound 3; then compound 4; then compound 2. At a limit, above all of these: compound 1.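

In this assay, replacing 3-bromophenyl with 4-chlorophenyl on the carbonyl carbon moves the number by more than the scatter: a 2.3-fold higher number from compound 3 to compound 4 (0.37 log units; beyond the scatter). Both groups sit lower than 2-bromophenyl, now with a second step in that direction, a 3.4-fold lower number from compound 2 to compound 4 (0.53 log units; beyond the scatter), so 2-bromophenyl gives the highest number of the three halogen-bearing phenyl groups. Nothing at hand gives a cause for this order.

The step from 3-bromophenyl to 4-chlorophenyl changes the halogen and its place on the phenyl ring together, so the compounds shown cannot say which of the two accounts for it. Also open, from the compounds shown here alone, is how an amine or a carboxylic acid in place of the halogen on the phenyl ring would read in this assay.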